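Aromatic methyl added to the indole-bearing core of compound 2

A few compounds are considered here, and "the series" means these few. Any claim that something is new, unique, unknown or untested is made for them only; others in the source may bear on it.

Compound 2, `COC(=O)[C@@]1(C)CCC=C2[C@@H]1CC[C@@H](C)[C@]2(C)Cc1c(C)[nH]c2ccccc12`, was tested in a functional assay on HeLa cells (Homo sapiens) for inhibition, read by sulforhodamine B assay, with a stated time of 48 h (on this read-out higher numbers stand for weaker inhibition of growth and lower numbers for stronger inhibition of growth), where compound 2 gives 11000 nM. Among the three measured compounds it stands second highest. Its nearest neighbour is compound 3, `COC(=O)[C@@]1(C)CCC=C2[C@@H]1CC[C@@H](C)[C@]2(C)Cc1c(C)[nH]c2ccc(Cl)cc12`, which gives 12000 nM; the step of a 1.1-fold higher number from compound 2 to compound 3 (0.04 log units; within the scatter) is within the scatter. Furthest from it is compound 1, `COC(=O)[C@@]1(C)CCC=C2[C@@H]1CC[C@@H](C)[C@]2(C)Cc1c[nH]c2c(C)cccc12`, which gives 4900 nM, a gap beyond the scatter.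

Compound 4, `COC(=O)[C@@]1(C)CCC=C2[C@@H]1CC[C@@H](C)[C@]2(C)Cc1c(C)[nH]c2c(C)cccc12`, differs from compound 2 by methyl in place of hydrogen on an aromatic carbon. Among the measured compounds shown here, only one measured step bears on substitution of this ring: a 1.1-fold higher number from compound 2 to compound 3 (0.04 log units; within the scatter), a change too small to count. Compound 1 also carries a methyl on this ring, though it lacks the methyl on the pyrrole carbon that compounds 2 and 4 share, so its lower number can only be read as a hint. Compound 4 is therefore expected to give a somewhat lower number than compound 2, estimated as a 1.6-fold lower number from compound 2 to compound 4 (0.20 log units; within the scatter). The estimate for compound 4 in this assay is 7000 nM, with a range from 2500 nM to 20000 nM.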

Compound 4, concentration for 50% growth inhibition: 14000 nM
Compound 4: middle estimate off by 2.0-fold (0.30 log units), on the low side; the range from low to high includes it.
By their numbers in this assay, from the lowest: compound 1; then compounds 2, 3 and 4 (each within the scatter of the next).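

In this assay, methyl in place of hydrogen on this carbon of the six-membered aromatic ring, ortho to a fused ring, gives a 1.3-fold higher number from compound 2 to compound 4 (0.10 log units; within the scatter), so this change does not measurably alter growth inhibition when the other methyl is present. Among the compounds shown here, the one step here that exceeds the scatter is the addition of the methyl that compound 4 carries and compound 1 lacks, a 2.9-fold higher number from compound 1 to compound 4 (0.46 log units; beyond the scatter), a modest move towards weaker inhibition of growth. No measurement is available to explain this difference.

The compounds shown leave open whether an amine or a methoxy group on this ring carbon would move the number. They also leave open whether the ring methyl would have any measurable effect on a core with hydrogen on the other aromatic carbon.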